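Closing the phenylethyl group into an indane ring

The compounds below may be only part of what the source reports. "The series", "measured", "known", "first", "only" and "open" are said of these compounds alone.

Measured so far in an assay on CHO cells for displacement of a labelled ligand from 5-hydroxytryptamine receptor 1B (Homo sapiens); a higher number here means a weaker inhibitor, a lower number a stronger inhibitor:
compound 2 `C[C@H](NCC1CCN(CCCc2c[nH]c3ccc(-n4cnnc4)cc23)CC1)c1ccccc1` gives 58 nM;
compound 1 `O[C@H]1Cc2ccccc2C1NC1CCN(CCCc2c[nH]c3ccc(-n4cnnc4)cc23)CC1` gives 300 nM.

Compound 2 has the lower of the two numbers, so it is the stronger inhibitor. Compound 3 `c1ccc2c(c1)CCC2NCC1CCN(CCCc2c[nH]c3ccc(-n4cnnc4)cc23)CC1` differs from it by 2,3-dihydro-1H-inden-1-yl in place of 1-phenylethyl on an amine nitrogen. Among the measured compounds shown here, the only measured step, a 5.2-fold lower number from compound 1 to compound 2 (0.71 log units; beyond the scatter), changed two things at once, so no step isolates this single change. The closest comparison is compound 1, which also carries a 2,3-dihydro-1H-inden-1-yl group and gives 300 nM. With so little to go on, compound 3 is expected to stay near compound 2, with a 1.2-fold higher number from compound 2 to compound 3 (0.08 log units; within the scatter). The estimate for compound 3 is 70 nM, with a range of 25 nM to 200 nM.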

Compound 3, half-maximal inhibitory concentration: 25 nM
Estimate against measurement, compound 3: 2.8-fold (0.45 log units) above; low and high end bracket the measured number.
By their numbers in this assay, from the lowest: compound 3; then compound 2; then compound 1.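

In this assay, 2,3-dihydro-1H-inden-1-yl in place of 1-phenylethyl on the amine nitrogen gives a 2.3-fold lower number from compound 2 to compound 3 (0.37 log units; beyond the scatter), so closing the ring is tolerated here and even brings a modest gain. Among the compounds shown here, the larger change gives a 12-fold lower number from compound 1 to compound 3 (1.08 log units; beyond the scatter) and is the biggest step so far, but it alters two things at once: it removes the hydroxyl and adds the methyl link. No measurement here explains either gain.

Which of those two alterations matters most remains open. So does whether a fluorine or a methoxy group on the 2,3-dihydro-1H-inden-1-yl ring would be accepted.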